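The compounds below may be only part of what the source reports. "The series", "measured", "known", "first", "only" and "open" are said of these compounds alone.

Measured in a functional assay on cells (Endothelial cell, Sus scrofa) for antiproliferative activity; a higher number here means a weaker inhibitor, a lower number a stronger inhibitor:
- compound 1 `CO[C@@H]1[C@H](OC(=O)NC(=O)CCl)CO[C@]2(COC(C)(C)O2)[C@]1(CCCCCc1ccccc1)OC(=O)NC(=O)CCl`: 800 nM
- compound 2 `C=C(C)[C@@]1(O)[C@H](OC)[C@H](OC)CO[C@]12CO2`: > 500000 nM (a limit of the assay)
- compound 3 `CO[C@@H]1[C@H](OC(=O)NC(=O)c2ccccc2)CO[C@]2(COC(C)(C)O2)[C@@]1(O)C1(C)CO1`: 363000 nM

Compound 1 holds the lowest number in this small set, at 800 nM. Compound 3 reads far higher at 363000 nM, a gap well beyond the usual scatter. Compound 2 gives > 500000 nM, which is a limit and not a number.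

The next compound to be tested is compound 4 `CO[C@@H]1[C@H](OC(=O)NC(=O)CCl)CO[C@]2(COC(C)(C)O2)[C@@]1(OC(=O)NC(=O)CCl)C1OC1CCCc1ccccc1`, which differs from compound 1 in one place. On a saturated ring carbon, 3-(3-phenylpropyl)oxiran-2-yl stands in place of 5-phenylpentyl: 3-(3-phenylpropyl)oxiran-2-yl in place of 5-phenylpentyl on a saturated ring carbon. The rest of compound 1 stays as it is.

Within the data shown here, no measured step in this assay isolates a change of this kind, so the expectation is loose. Compound 3 also carries an oxirane and reads 363000 nM, but it differs from compound 1 in more than one place and offers little guide to this swap. Compound 4 keeps a phenyl-ending chain, as compound 1 at 800 nM does, so it is expected to stay close to that compound, with no step beyond the scatter. The estimated step runs a 1.3-fold lower number from compound 1 to compound 4 (0.12 log units; within the scatter). For compound 4 the expected value is 600 nM, with an estimated range from 80 nM to 5000 nM.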

Compound 4, half-maximal inhibitory concentration: 16000 nM
Beside the measured number, compound 4's estimate is 27-fold (1.43 log units) below it; the whole stated range lies below it.
By their numbers in this assay, from the lowest: compound 1; then compound 4; then compound 3. At a limit, above all of these: compound 2.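

In this assay, putting 3-(3-phenylpropyl)oxiran-2-yl in place of 5-phenylpentyl on this saturated ring carbon gives a 20-fold higher number from compound 1 to compound 4 (1.30 log units; beyond the scatter), so this position is sensitive to the make-up of its chain and not only to the presence of a chain. The entering group still ends in a phenyl ring, so a phenyl-ending chain alone does not hold the number at the level of compound 1, 800 nM; the three-membered ring with its oxygen is the feature that comes in with the step. Nothing measured here accounts for the size of this step.

The compounds shown leave open whether the step follows the oxygen or the three-membered ring itself, a question that a cyclopropane or a plain alkene at the same place in the chain would help to separate. They also leave open how the number at this position responds to chain length and to the chain end, for instance with a longer chain than 5-phenylpentyl or with an amine in place of the terminal phenyl ring.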